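This account rests on a few compounds, and the source may have more. Where it says the series, first, only, none or still open, it means among the compounds named here.

Of the compounds shown here, three of a shared core have been tested in an assay for inhibition of Tryptophan 2,3-dioxygenase (Homo sapiens), with stated times of 10 min and 60 min, tested at 10 uM; on this read-out lower numbers stand for a weaker effect and higher numbers for a stronger effect at the one concentration tested. Compound 1 `O=C(O)c1cccc(CNc2cc(C(F)(F)F)cc3[nH]ncc23)c1` carries a carboxy on its aromatic ring and gives 81% in this assay. Compound 2 `O=[N+]([O-])c1cccc(CNc2cc(Br)cc3[nH]ncc23)c1` gives 91%, a number higher than that of compound 1 by a margin that stays within the usual scatter, so the two cannot be ranked against each other. Compound 3 `N#Cc1cc(NCc2ccccc2[N+](=O)[O-])c2cn[nH]c2c1` gives 22%, well below compound 1 and beyond the scatter. Compound 1 therefore stands with compound 2 at the upper end of the three numbers, and far above compound 3.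

Compound 4 `FC(F)(F)c1cccc(CNc2cc(C(F)(F)F)cc3[nH]ncc23)c1` has not yet been measured. It differs from compound 1 in one place: trifluoromethyl in place of carboxy on an aromatic carbon. Among the measured compounds shown here, no pair of measured compounds shows a step of exactly this kind, so the size of the step in this assay is open. The nearest hint is compound 2, where a group other than carboxy on the same aromatic ring still gives 91%. On that basis compound 4 is expected to stay in the upper range, with a step of a number 6 percentage points lower from compound 1 to compound 4 (within the scatter) that may well lie within the scatter. The estimate for compound 4 is 75%, between 45% and 95%.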

Compound 4, a percentage reported as inhibition, at one concentration (the size of the read-out at that concentration, not a potency): 40%
Compound 4: middle estimate off by 35 percentage points, on the high side; the whole stated range lies above it.
By their numbers in this assay, from the lowest: compound 3; then compound 4; then compounds 1 and 2 (each within the scatter of the next).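

Trifluoromethyl in place of carboxy on this aromatic carbon, with the rest of the molecule unchanged, gives a number 41 percentage points lower from compound 1 to compound 4 (beyond the scatter) in this assay, so the high number of compound 1 does not survive this exchange. The group at this place therefore matters to the read-out, and a swap between two small groups without a ring can be enough to change it: carboxy brings a hydrogen-bond donor and a hydrogen-bond acceptor, while trifluoromethyl brings neither. That difference is only a count of features, and no supporting data on this series bear on what lies behind the step.

A single exchange cannot separate the part played by the hydrogen-bond donor from that of the acceptor or of any other difference between the two groups. A primary amide, a hydroxymethyl group or a methyl ester at this same place would help to show which part of carboxy goes with the higher number, and whether the step keeps its size on the other compounds of the shared core is also unknown.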